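Replacing the Ester of Compound 1 with a Hydroxybutyl Chain

The source may report more compounds than this note shows. Statements on the series, on what has been measured and on what is new or still open speak of the compounds shown alone.

Compound 1 `CCOC(=O)C(Cc1cccc(OCC(=O)O)c1)c1nc(-c2ccccc2)c(-c2ccccc2)o1` gives the lowest number of the three measured in a functional assay for inhibition, with Homo sapiens as the target (on this read-out lower numbers stand for stronger inhibition and higher numbers for weaker inhibition), at 120 nM. Compound 2 `CC(C)OC(=O)C(Cc1cccc(OCC(=O)O)c1)c1nc(-c2ccccc2)c(-c2ccccc2)o1` gives 1220 nM, and compound 3 `C[S+]([O-])C(Cc1cccc(OCC(=O)O)c1)c1nc(-c2ccccc2)c(-c2ccccc2)o1` gives 7080 nM. Compound 4 `O=C(O)COc1cccc(CC(CCCCO)c2nc(-c3ccccc3)c(-c3ccccc3)o2)c1` differs from compound 1 by 4-hydroxybutyl in place of ethoxycarbonyl on a saturated chain carbon bound to an aromatic carbon and a saturated chain carbon. Within the data shown here, two measured steps bear on this change: a 10-fold higher number from compound 1 to compound 2 (1.01 log units; beyond the scatter) and a 59-fold higher number from compound 1 to compound 3 (1.77 log units; beyond the scatter). Both alter the group on the same saturated chain carbon and both weaken inhibition, the larger loss coming where the ester leaves altogether. The change to compound 4 likewise removes the ester, so a large rise in the number is expected. Compound 4 is therefore estimated at 3000 nM, within 800 nM to 12000 nM. The expected step is a 25-fold higher number from compound 1 to compound 4 (1.40 log units; beyond the scatter).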

Compound 4, half-maximal inhibitory concentration: 4680 nM
Compound 4: the middle estimate sits 1.6-fold (0.19 log units) below what was measured, within the range that was stated.
By their numbers in this assay, from the lowest: compound 1; then compound 2; then compounds 4 and 3 (each within the scatter of the next).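

At this saturated chain carbon, 4-hydroxybutyl matches ethoxycarbonyl in heavy atoms yet does not keep the inhibition, with a 39-fold higher number from compound 1 to compound 4 (1.59 log units; beyond the scatter) as the result. It also trails the isopropoxycarbonyl group, with a 3.8-fold higher number from compound 2 to compound 4 (0.58 log units; beyond the scatter) on that comparison, while a 1.5-fold lower number from compound 3 to compound 4 (0.18 log units; within the scatter) leaves it level with the group of compound 3. Both non-ester groups shown thus stand apart from both esters. No evidence on the cause of this loss is at hand.

Going by these compounds, whether an amide or a carboxylic acid at this carbon would restore inhibition stays open, as does the effect of a shorter hydroxyalkyl chain.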